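Second Fluorine on the Benzyl Ring of Compound 3

This account rests on a few compounds, and the source may have more. Where it says the series, first, only, none or still open, it means among the compounds named here.

The study concerns three measured compounds and one that is yet to be measured, all tested in a functional assay on SW 1116 cells (Homo sapiens) for antiproliferative activity, read by MTT assay, with a stated time of 48 h; on this read-out lower numbers stand for stronger inhibition and higher numbers for weaker inhibition. Compound 2 `c1ccc(CSc2nnc(-c3cnccn3)o2)cc1` gives 34000 nM. Compound 1 `Fc1ccccc1CSc1nnc(-c2cnccn2)o1` gives 16800 nM. The change between these two is fluoro in place of hydrogen on an aromatic carbon, and it produced a 2.0-fold lower number from compound 2 to compound 1 (0.31 log units; beyond the scatter). Compound 3 `Fc1ccccc1CSc1nnc(-c2cnccn2)s1` gives 6770 nM, the lowest number of the three; how its core differs from the core of compound 2 is not broken down here.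

Compound 4 `Fc1cccc(F)c1CSc1nnc(-c2cnccn2)s1` is the unmeasured compound. It differs from compound 3 by fluoro in place of hydrogen on an aromatic carbon. Within the data shown here, this is the same kind of change as the one from compound 2 to compound 1, but the surroundings are not identical: in compound 4 the entering fluoro sits ortho to a large group and meta to a fluoro group, whereas in compound 1 it sits only ortho to a large group.

Resting on the step from compound 2 to compound 1 in this assay, the step from compound 3 to compound 4 is expected to be a 1.8-fold lower number from compound 3 to compound 4 (0.25 log units; within the scatter). Compound 4 is therefore estimated at 3800 nM, within a range from 1800 nM to 8000 nM.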

Compound 4, half-maximal inhibitory concentration: 16800 nM
For compound 4 the middle estimate is 4.4-fold (0.65 log units) below the measured one, and the stated range ends below it.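

In this assay the entering fluoro gave a 2.5-fold higher number from compound 3 to compound 4 (0.39 log units; beyond the scatter), so the change did not repeat the direction it took on the other core, and the two steps are clearly apart: the same change on two cores in this assay, a 2.0-fold lower number (0.31 log units; beyond the scatter) from compound 2 to compound 1 and a 2.5-fold higher number (0.39 log units; beyond the scatter) from compound 3 to compound 4, 5.0-fold (0.70 log units) apart, beyond the scatter of two such steps This shows that, in this series, the replacement of hydrogen by fluoro on an aromatic carbon cannot be carried from one core to another as a fixed step. It does not show what sets the two steps apart, since the pairs differ in two ways at once: the core is different, and the entering fluoro in compound 4 sits meta to a fluoro group as well as ortho to a large group, whereas in compound 1 it sits only ortho to a large group.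

The compounds shown leave open whether the same second fluoro on the core of compound 1 would raise the number too. They also leave open how a chloro group, a methoxy group or an amine on this ring would behave on either core.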